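Adding a phenyl ring to a thiosemicarbazone antiproliferative

The source may hold more compounds than are shown below. What is called first, only, known or untested is meant among the compounds shown, and "the series" means these compounds.

Three thiosemicarbazones have been tested in a functional assay on HEp-2 cells (Homo sapiens) for antiproliferative activity, read by MTT assay, with a stated time of 72 h; on this read-out higher numbers stand for weaker inhibition and lower numbers for stronger inhibition. Compound 1 `Oc1ccc2ccccc2c1/C=N/NC(=S)Nc1ccccc1` gives 700 nM in this assay. Compound 2 `COc1cccc(/C=N/NC(=S)Nc2ccccc2)c1O` gives 1600 nM in this assay. Compound 3 `CCN(CC)c1ccc(/C=N/NC(N)=S)c(O)c1`, the only one of the three with an unsubstituted terminal nitrogen, gives 900 nM in this assay. All three numbers lie close together: the gap between compound 3 and compound 1 falls within the usual scatter of repeated measurements, and so does the gap between compound 3 and compound 2, so no order among them can be claimed.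

Compound 4 `CCN(CC)c1ccc(/C=N/NC(=S)Nc2ccccc2)c(O)c1` has not yet been measured. It differs from compound 3 in one place: phenyl in place of hydrogen on an amide-type nitrogen. Compounds 1 and 2 already carry this phenyl on the same nitrogen, with different aromatic parts on the other side of the molecule, and their values bracket that of compound 3 closely. Going by the values given here, since no pair of measured compounds differs by exactly this change, the step can only be guessed from that neighbourhood. The expected step in this assay from compound 3 to compound 4 is therefore small, a 1.1-fold lower number from compound 3 to compound 4 (0.05 log units; within the scatter), with no direction beyond the scatter. Compound 4 is estimated to give 800 nM in this assay, within a range from 300 nM to 2500 nM.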

Compound 4, half-maximal inhibitory concentration: 300 nM
Compound 4: the middle estimate sits 2.7-fold (0.43 log units) above what was measured; low and high end bracket the measured number.
By their numbers in this assay, from the lowest: compound 4; then compounds 1, 3 and 2 (each within the scatter of the next, the first and the last beyond it).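

In this assay, going by these compounds alone, phenyl in place of hydrogen on the amide-type nitrogen gives a 3.0-fold lower number from compound 3 to compound 4 (0.48 log units; beyond the scatter), and this is the first step that can be read on its own. The earlier compounds shown here could not show this, since no two of them differed in one place, and any effect of what sits on this nitrogen was mixed up with changes in the aromatic part on the other side of the molecule. With the rest of the molecule held fixed, the change from amino to anilino moves the number beyond the scatter, so this position is not indifferent to what it carries, although the step is modest and rests on a single pair, and nothing available here explains why the number moves.

The compounds shown leave open whether the same step would appear with the aromatic parts of compound 1 and compound 2, as neither has a partner with hydrogen on this nitrogen. Also open, as far as these compounds go, is whether an aromatic ring is needed here at all, or whether a methyl group, a longer chain such as butyl, or a saturated cyclohexyl ring would give a similar number.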